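A few compounds are considered here, and "the series" means these few. Any claim that something is new, unique, unknown or untested is made for them only; others in the source may bear on it.

Compound 2 `COc1ccc(C2C(C#N)=C(N)N(c3ccc(S(N)(=O)=O)cc3)C3=C2CCCC3)cc1` carries a 4-methoxyphenyl group on a saturated ring carbon of the shared core. In a functional assay on Ehrlich cells (Mus musculus) for cytotoxicity, read by trypan blue exclusion, with a stated time of 2 h, tested at 100 ug/mL (a higher number here means a stronger effect of the compound at the concentration tested, a lower number a weaker effect), compound 2 gives 100%. Compound 1 `N#CC1=C(N)N(c2ccc(S(N)(=O)=O)cc2)C2=C(CCCC2)C1c1ccccc1O` bears a 2-hydroxyphenyl group at that same carbon, and in this assay compound 1 gives 100%, so the two stand level, together the highest of the three numbers; the step of no change at the digits printed from compound 1 to compound 2 (within the scatter) lies within the scatter. Compound 3 `COc1ccc(C2C(C#N)=C(N)N(c3ccc(S(N)(=O)=O)cc3)C3=C2CCCC3)c2ccccc12` is the third measured member, and in this assay compound 3 gives 20%, a number far lower than that of compound 2 and beyond the scatter.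

Compound 4 `N#CC1=C(N)N(c2ccc(S(N)(=O)=O)cc2)C2=C(CCCC2)C1c1cccs1` has not yet been measured. It differs from compound 2 by thiophen-2-yl in place of 4-methoxyphenyl on a saturated ring carbon. Within the data shown here, only one measured step bears directly on such an exchange of one aromatic group for another on the same saturated ring carbon: no change at the digits printed from compound 1 to compound 2 (within the scatter), which brought no change beyond the scatter. Among the measured compounds shown here, compound 3 shows that not every group at this carbon keeps the full effect, but no single-point step links compound 3 to compound 2. The step of a number 10 percentage points lower from compound 2 to compound 4 (within the scatter) is therefore expected to be small, with the low number of compound 3 as a caution. Compound 4 is estimated at 90% in this assay, within a range from 55% to 100%.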

Compound 4, a percentage reported as activity, at one concentration (the size of the read-out at that concentration, not a potency): 20%
Estimate against measurement, compound 4: 70 percentage points above; measured number outside the range, below it.
By their numbers in this assay, from the lowest: compounds 3 and 4 (each within the scatter of the next); then compounds 1 and 2 (each within the scatter of the next).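

Thiophen-2-yl in place of 4-methoxyphenyl brings a number 80 percentage points lower from compound 2 to compound 4 (beyond the scatter) in this assay and thiophen-2-yl in place of 2-hydroxyphenyl brings a number 80 percentage points lower from compound 1 to compound 4 (beyond the scatter) on the same saturated ring carbon, so this position does respond to the choice of aromatic group. The earlier single step at this carbon, between two phenyl groups that each carry one substituent, showed no change beyond the scatter, and it now appears that those two groups do not speak for every aromatic group placed here. In this assay compound 3 gives 20% and stands level with compound 4 at 20% in this comparison, so two quite different groups at this carbon share the same low number.

The compounds shown do not separate the part played by the sulfur atom from that of the five-membered ring or of the missing substituent, and a furan-2-yl or a plain phenyl group at this carbon would bear on that question. Nothing measured here explains why the number falls so far with thiophen-2-yl.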